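From 2-fluorobenzyl to 4-chlorobenzyl: one group exchanged

This account rests on a few compounds, and the source may have more. Where it says the series, first, only, none or still open, it means among the compounds named here.

Within the data shown here, in a functional assay on HeLa cells (Homo sapiens) for inhibition, with a stated time of 72 h (on this read-out lower numbers stand for an effect already at smaller amounts and higher numbers for an effect only at larger amounts of compound), compound 2 (`COc1cc(CNCc2ccncc2)ccc1OCc1ccccc1F`) gives 5100 nM, the lowest number so far. Compound 1 (`COc1cc(CNCc2ccccc2)ccc1OCc1ccc(Cl)nc1`) gives 90000 nM, a higher number well beyond the usual scatter. Compound 3 (`COc1cc(CNCc2ccc(C(=O)O)cc2)ccc1OCc1ccc(Cl)nc1`) has no number, and its entry reads "nd(insoluble)" (no result reported). Compound 4 (`COc1cc(CNCc2ccncc2)ccc1OCc1ccc(Cl)cc1`) is still unmeasured. It differs from compound 2 by carrying 4-chlorophenyl in place of 2-fluorophenyl on a saturated chain carbon bound to an oxygen on an aromatic ring. Among the measured compounds shown here, no measured pair differs in only one place, so the data offer no direct guide to this change. In this assay, the expectation is no step beyond the scatter, in either direction. The estimated step is a 1.2-fold higher number from compound 2 to compound 4 (0.07 log units; within the scatter). For compound 4, the expected value is 6000 nM, with an estimated range of 1800 nM to 20000 nM.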

Compound 4, half-maximal effective concentration: 890 nM
Compound 4: the middle estimate sits 6.7-fold (0.83 log units) above what was measured, outside the stated range (below it).
By their numbers in this assay, from the lowest: compound 4; then compound 2; then compound 1.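

In this assay, among these compounds, the first comparison that changes only one place shows a 5.7-fold lower number from compound 2 to compound 4 (0.76 log units; beyond the scatter) with 2-fluorophenyl leaving and 4-chlorophenyl entering. This position therefore responds to the group it carries, even though both groups have the same heavy-atom count and neither has hydrogen-bond donors or acceptors. Nothing measured here explains the step. From the compounds shown here alone, both the halogen and its place on the ring change together, so their separate contributions remain open. Going by these compounds, how a plain phenyl group would read at this position also remains open.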